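The source may hold more compounds than are shown below. What is called first, only, known or untested is meant among the compounds shown, and "the series" means these compounds.

Compound 1 `CCCc1cc(NC2CCC2)c2cc(NC(=O)/C=C/c3ccc(C(F)(F)F)cc3)ccc2n1` is the reference point here. In an assay on isolated protein for displacement of a labelled ligand from melanin-concentrating hormone receptor 1 (Homo sapiens) (a higher number here means a weaker inhibitor, a lower number a stronger inhibitor), compound 1 gives 18 nM. Two further compounds share its core. Compound 2 `CCCc1cc(N)c2cc(NC(=O)/C=C/c3ccc(O)cc3)ccc2n1` gives 1100 nM in this assay, and compound 3 `CCCc1cc(N)c2cc(NC(=O)/C=C/c3cccc(Cl)c3)ccc2n1` gives 1100 nM in this assay. Compound 1 thus stands lowest of the three numbers, and its distance to both compound 2 and compound 3 lies well beyond the usual scatter. Each of those two, however, differs from compound 1 in two places at once, at the amine on the core and at the far end of the double-bonded chain, so the share of the amine alone cannot be read from them. Within the data shown here, the only step between compounds that differ in one place, no change at the digits printed from compound 2 to compound 3 (within the scatter), concerns the far end of the chain and leaves the amine untouched.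

Compound 4 `CCCc1cc(N(C)C)c2cc(NC(=O)/C=C/c3ccc(C(F)(F)F)cc3)ccc2n1` differs from compound 1 by dimethylamino in place of cyclobutylamino on an aromatic carbon. Among the measured compounds shown here, no measured step speaks to this change, so the expectation rests on compound 1 alone and carries wide uncertainty. Compound 4 is expected to stay near compound 1, with some room for a weaker result, a 2.8-fold higher number from compound 1 to compound 4 (0.44 log units; beyond the scatter). Compound 4 is therefore estimated at 50 nM, within a range from 10 nM to 300 nM.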

Compound 4, half-maximal inhibitory concentration: 43 nM
Beside the measured number, compound 4's estimate is 1.2-fold (0.07 log units) above it; the range from low to high includes it.
By their numbers in this assay, from the lowest: compound 1; then compound 4; then compounds 2 and 3 (each within the scatter of the next).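

In this assay, the amine on the shared core can now be read on its own, as the far end of the double-bonded chain stays the same in this pair: dimethylamino in place of cyclobutylamino gives a 2.4-fold higher number from compound 1 to compound 4 (0.38 log units; beyond the scatter). This swap removes the four-membered ring, goes from 5 heavy atoms to 3 and from 1 hydrogen-bond donor to 0, yet on this aromatic carbon opposite the ring nitrogen the step remains modest, though it lies beyond the scatter. Nothing measured here gives a reason for the shift.

The ring, the heavy-atom count and the donor all change in this single step, so the compounds shown cannot tell which of them accounts for the shift, or whether they act together. Methylamino, which has no ring but keeps the hydrogen on the nitrogen, and pyrrolidine attached through its nitrogen, which keeps a ring but has no such hydrogen, are two groups that could help to pull these changes apart at this position.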